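Piperazine-linked aryl variation in the sigma-1 series

This account rests on a few compounds, and the source may have more. Where it says the series, first, only, none or still open, it means among the compounds named here.

Compound 1 `COC(=O)C1(c2ccccc2)CC1CN1CCN(c2ncccn2)CC1` is the parent of the shared core; in an assay for displacement of a labelled ligand from Sigma non-opioid intracellular receptor 1 (Cavia porcellus) (on this read-out higher numbers stand for weaker inhibition and lower numbers for stronger inhibition), compound 1 gives 3090 nM. Compound 2 `COC(=O)C1(c2ccc(N)cc2)CC1CN1CCN(c2ncccn2)CC1` carries amino in place of hydrogen on an aromatic carbon. In this assay compound 2 reaches only a limit of the assay, > 10000 nM. The step of an at least 3.2-fold higher number from compound 1 to compound 2 (0.51 log units; beyond the scatter) is thus weakening, and its exact size is open because of the limit of > 10000 nM in this assay, at which 1 of the 3 values shown sits. Compound 3 `COC(=O)C1(c2ccccc2)CC1CN1CCC(Cc2ccccc2)CC1` differs from compound 1 in more than one place; in this assay compound 3 gives 2.2 nM, far stronger than compound 1.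

Compound 4 `COC(=O)C1(c2ccc(N)cc2)CC1CN1CCN(c2ccccn2)CC1` keeps the amino-bearing aryl of compound 2 and changes the group on the ring nitrogen: pyridin-2-yl in place of pyrimidin-2-yl on an amine nitrogen in a ring. Within the data shown here, no measured step here touches that group; the only measured step, from compound 1 to compound 2, concerns the aryl carbon instead. With compound 2 standing at a limit, the estimate for compound 4 in this assay is 10000 nM, with the range 3000 nM to 30000 nM. The expected step is a number no higher from compound 2 to compound 4 (the limit leaves the size open), with a fair chance that compound 4 again returns only a limit.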

Compound 4, inhibition constant: > 10000 nM
Compound 4: only a limit was reported; the forecaster's own chance of this, stated with the estimate: 55%; the middle value sits exactly at the limit.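

No step can be read from compound 2 to compound 4, because in this assay both return only a limit: the limit of > 10000 nM in this assay, at which 2 of the 4 values shown sit.

The compounds shown leave open how pyridin-2-yl and pyrimidin-2-yl on an amine nitrogen in a ring compare when the aryl carries amino.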